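A few compounds are considered here, and "the series" means these few. Any claim that something is new, unique, unknown or untested is made for them only; others in the source may bear on it.

This series of amides shares a trimethoxyphenyl-bearing core and is tested in a functional assay on QGY cells (Homo sapiens) for cytotoxicity, read by MTT assay, with a stated time of 48 h; a lower number here means a stronger inhibitor, a higher number a weaker inhibitor. In this test, compound 1 `COc1cc([C@@H]2C[C@@]2(CO)C(=O)Nc2ccccc2)cc(OC)c1OC` gives 36700 nM, while compound 2 `COc1cc([C@@H]2C[C@]2(CO)C(=O)Nc2ccccc2Cl)cc(OC)c1OC` gives 15700 nM. Compound 3 `CCOC(=O)[C@@]1(C(=O)Nc2ccccc2)C[C@@H]1c1cc(OC)c(OC)c(OC)c1` returns only a limit, > 100000 nM, rather than an exact number. Compound 2 therefore holds the lower of the two exact numbers, and its gap to compound 1 lies beyond the usual scatter of repeated measurements.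

The next compound to be tested is compound 4 `COc1cc([C@@H]2C[C@]2(CO)C(=O)NCc2ccc(C)cc2)cc(OC)c1OC`, which has 4-methylbenzyl in place of 2-chlorophenyl on an amide-type nitrogen. For the measured compounds named here, none of the measured compounds carries this 4-methylbenzyl group, so there is no direct precedent for the size of this change, and any forecast must remain loose. Going by the values given here, compound 2 holds the lowest number so far, and compound 1 at 36700 nM lies higher, so a moderate step towards a higher number, meaning a weaker inhibitor, is expected, probably just beyond the scatter. The estimated change is a 2.2-fold higher number from compound 2 to compound 4 (0.35 log units; beyond the scatter). In this assay, compound 4 is expected to give 35000 nM, with an estimated range of 10000 nM to 100000 nM.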

Compound 4, half-maximal inhibitory concentration: 25100 nM
Compound 4: middle estimate off by 1.4-fold (0.14 log units), on the high side, within the range that was stated.
By their numbers in this assay, from the lowest: compounds 2, 4 and 1 (each within the scatter of the next, the first and the last beyond it). At a limit, above all of these: compound 3.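

In this assay, placing 4-methylbenzyl instead of 2-chlorophenyl on the amide-type nitrogen gives a 1.6-fold higher number from compound 2 to compound 4 (0.20 log units; within the scatter), so the two compounds cannot be told apart in this test. For the compounds shown here, compound 1, compound 2 and compound 3 carry only phenyl or 2-chlorophenyl on this nitrogen, so compound 4 is the first sign that a benzyl-type group can sit here without a clear loss of activity, even with the chlorine gone. No measured property of these compounds speaks to why the swap leaves the result so little changed.

This single step alters the ring's substituent and the way the ring joins the nitrogen at once, so plain benzyl or 2-chlorobenzyl on the same nitrogen would be needed to separate the two changes. Also open, as far as these compounds go, is whether a longer chain such as 2-phenylethyl, or a ring bearing an amine or a carboxylic acid, would move the number clearly in either direction.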